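Shortening the Amine Chain of a Sulfonamide

The compounds below may be only part of what the source reports. "The series", "measured", "known", "first", "only" and "open" are said of these compounds alone.

Within the data shown here, in a functional assay on HEK293 cells (Homo sapiens) for inhibition (on this read-out lower numbers stand for stronger inhibition and higher numbers for weaker inhibition), compound 1 (`CCCCCCCCCCCCS(=O)(=O)NCCCNCCCNCCCCNCCCN`) gives 190 nM, the lower of the two numbers so far, and compound 2 (`CCCCCCCCCCCCCCCCCCS(=O)(=O)NCCCNCCCNCCCCNCCCN`) gives 1060 nM. Compound 3 (`CCCCCCCCCCCCS(=O)(=O)NCCCNCCCNCCCN`) differs from compound 1 by a single change: amino in place of ((3-aminopropyl)amino)methyl on a saturated chain carbon, three bonds along the chain from an amine nitrogen. Among the measured compounds shown here, the only measured step, a 5.6-fold higher number from compound 1 to compound 2 (0.75 log units; beyond the scatter), alters a different part of the structure, so it offers only a rough guide to size. A modest rise of similar scale is the expected outcome in this assay, estimated as a 2.6-fold higher number from compound 1 to compound 3 (0.42 log units; beyond the scatter), though the direction remains uncertain. The estimated value for compound 3 is 500 nM, with an expected range from 120 nM to 2000 nM.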

Compound 3, half-maximal inhibitory concentration: 363 nM
Compound 3: the middle estimate sits 1.4-fold (0.14 log units) above what was measured; the measured number falls inside the stated range.
By their numbers in this assay, from the lowest: compounds 1 and 3 (each within the scatter of the next); then compound 2.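

Putting amino in place of ((3-aminopropyl)amino)methyl, on a saturated chain carbon three bonds along the chain from an amine nitrogen, gives a 1.9-fold higher number from compound 1 to compound 3 (0.28 log units; within the scatter) in this assay. So at this position, compound 3 keeps the read-out within the usual scatter of compound 1 despite carrying fewer heavy atoms in its amine chain. Nothing available explains this result. Still open, from the compounds shown here alone, is whether a shorter amine chain would stay within that scatter too. Also open, going by these compounds, is how a carboxylic acid in place of the amino would read.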